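The source may hold more compounds than are shown below. What is called first, only, known or untested is meant among the compounds shown, and "the series" means these compounds.

Measured so far in a physicochemical assay for solubility; on this read-out higher numbers stand for higher solubility and lower numbers for lower solubility:
Compound 1 `O=C(O)c1ccc(C(=O)/C(=C\c2ccc(Cl)c([N+](=O)[O-])c2)SCc2ccc(Cl)cc2)cc1`: < 1000 ug/mL, a limit.
Compound 2 `O=C(O)c1ccc(C(=O)/C(=C\c2ccc(O)c([N+](=O)[O-])c2)SCc2ccc(Br)cc2)cc1`: < 1000 ug/mL, a limit.
Compound 3 `COc1cc(/C=C(/SCc2ccc(Br)cc2)C(=O)c2ccc(C(=O)O)cc2)ccc1F`: < 1000 ug/mL, a limit.

Compound 3 thus stands only at a limit, < 1000 ug/mL, and has no exact number. It shares that position with the other two compounds: the limit of < 1000 ug/mL in this assay, at which 3 of the 3 values shown sit. Compound 4 `O=C(O)c1ccc(C(=O)/C(=C\c2cc([N+](=O)[O-])ccc2F)SCc2ccc(Br)cc2)cc1` differs from compound 3 at a single place: 2-fluoro-5-nitrophenyl in place of 4-fluoro-3-methoxyphenyl on a double-bonded chain carbon bound to a double-bonded chain carbon. Among the compounds with values here, the one measured step at this place is a step that the two limits leave unreadable from compound 2 to compound 3, so no size or direction carries over, and no step beyond the scatter is expected in this assay. The estimated change is a step that the limit leaves unreadable from compound 3 to compound 4. The estimate for compound 4 is 400 ug/mL. Its expected range runs from 60 ug/mL to 1000 ug/mL.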

Compound 4, solubility: < 1000 ug/mL
Compound 4: no number, only a limit; the forecaster's own chance of this, stated with the estimate: 85%; the middle value lies beyond the limit too.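

No step can be read between compound 2, compound 3 and compound 4 in this assay, since each gives only a limit: the limit of < 1000 ug/mL in this assay, at which 4 of the 4 values shown sit.

The compounds shown leave open whether 2-fluoro-5-nitrophenyl in place of 4-fluoro-3-methoxyphenyl changes this read-out at all, and by how much.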